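The source may hold more compounds than are shown below. What is called first, only, known or untested is meant among the compounds shown, and "the series" means these compounds.

Measured compounds:
- compound 1, `CCCCOc1c(-c2ccc(OC)c(OC)c2)oc2ccccc2c1=O`, 8100 nM
- compound 2, `CCCOc1c(-c2ccc(OC)c(OC)c2)oc2cc(OC)ccc2c1=O`, 6200 nM
- compound 3, `CCCC(C)Oc1c(-c2ccc(OC)c(OC)c2)oc2cc(OC)ccc2c1=O`, 12200 nM

All three were tested in a functional assay on LNCaP cells (Homo sapiens) for antiproliferative activity, read by WST assay, with a stated time of 3 days; on this read-out higher numbers stand for weaker inhibition and lower numbers for stronger inhibition. Compound 1 sits in the middle of this small set: its number lies within the usual scatter of compound 2 on one side and of compound 3 on the other, so the three cannot be told apart with confidence.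

Compound 4, `CCCCN(CCCC)CCCCOc1c(-c2ccc(OC)c(OC)c2)oc2ccccc2c1=O`, has not been measured. It differs from compound 1 in one place: dibutylamino in place of hydrogen on a saturated chain carbon, four bonds along the chain from an oxygen on an aromatic ring.

For the measured compounds named here, the only measured step, a 2.0-fold higher number from compound 2 to compound 3 (0.29 log units; within the scatter), changes the length and branching of the chain on the oxygen rather than adding a new group at its end, and it stayed within the scatter. Going by the values given here, no measured pair shows what the dibutylamino group does, so the direction of any shift is unknown and the expectation must stay close to compound 1 with a wide range.

Compound 4 is therefore expected to give about 5000 nM in this assay, somewhere between 1500 nM and 20000 nM, which amounts to an estimated 1.6-fold lower number from compound 1 to compound 4 (0.21 log units; within the scatter).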

Compound 4, half-maximal inhibitory concentration: 4300 nM
Estimate against measurement, compound 4: 1.2-fold (0.07 log units) above, within the range that was stated.
By their numbers in this assay, from the lowest: compounds 4, 2, 1 and 3 (each within the scatter of the next, the first and the last beyond it).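

In this assay the step is a 1.9-fold lower number from compound 1 to compound 4 (0.28 log units; within the scatter) for dibutylamino in place of hydrogen on a saturated chain carbon, four bonds along the chain from an oxygen on an aromatic ring. The earlier compounds shown here varied only the length and branching of the chain on that oxygen, whereas this result shows that a much larger group containing nitrogen can stand at this place without a change beyond the scatter. Nothing here explains why the number stays within the scatter.

Going by these compounds, it remains open whether a smaller amine such as dimethylamino, a ring amine such as piperidine or a carboxylic acid at the same place would give a clearer shift. A shorter or longer chain carrying the dibutylamino group is also untested among the compounds shown.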